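This account rests on a few compounds, and the source may have more. Where it says the series, first, only, none or still open, it means among the compounds named here.

Compound 1 `CC(C)c1ccc(Oc2ccc(O)c(O)c2)c(-c2ccsc2S(=O)(=O)NCCNC(=S)Nc2cc(C(F)(F)F)cc(C(F)(F)F)c2)c1` — 18100 nM
Compound 2 `O=C(NCCNS(=O)(=O)c1sccc1-c1ccccc1Oc1ccc(O)c(O)c1)Nc1cc(C(F)(F)F)cc(C(F)(F)F)c1` — 8900 nM
Compound 3 `CC(C)c1ccc(Oc2ccc(O)c(O)c2)c(-c2ccsc2S(=O)(=O)NCCNC(=O)Nc2cc(C(F)(F)F)cc(C(F)(F)F)c2)c1` — a limit, > 20000 nM

Of the compounds shown here, three have been tested in an ADME assay on HEK-293T cells (Homo sapiens) for cytotoxicity, read by CCK-8 assay, with a stated time of 48 h; on this read-out higher numbers stand for weaker inhibition and lower numbers for stronger inhibition. Compound 1 gives 18100 nM and compound 2 gives 8900 nM. For compound 3 the result is only a limit of the assay, > 20000 nM (the limit of > 20000 nM in this assay, at which 1 of the 3 values shown sits). Compound 2 arises from compound 3 by hydrogen in place of isopropyl on an aromatic carbon, and this step is an at least 2.2-fold lower number from compound 3 to compound 2 (0.35 log units; beyond the scatter). The difference between the core of compound 1 and the core of compound 3 is not broken down here.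

Compound 4 `O=S(=O)(NCCNC(=S)Nc1cc(C(F)(F)F)cc(C(F)(F)F)c1)c1sccc1-c1ccccc1Oc1ccc(O)c(O)c1` awaits measurement in this assay. It arises from compound 1 by hydrogen in place of isopropyl on an aromatic carbon, the same change as from compound 3 to compound 2. Resting on that earlier step, an at least 2.2-fold lower number from compound 3 to compound 2 (0.35 log units; beyond the scatter), the step is expected to be a 2.1-fold lower number from compound 1 to compound 4 (0.33 log units; beyond the scatter). Compound 4 is therefore estimated at 8500 nM, between 4000 nM and 18000 nM.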

Compound 4, half-maximal inhibitory concentration: 7500 nM
The estimate for compound 4 lay 1.1-fold (0.05 log units) above the measured number; low and high end bracket the measured number.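

In this assay, hydrogen in place of isopropyl on an aromatic carbon gives a 2.4-fold lower number from compound 1 to compound 4 (0.38 log units; beyond the scatter), which runs in the same direction as the change on the core of compound 3. This shows that the lower number recurs on a second core, but two cores make no rule for the series, and the size of the earlier step remains unsettled: the same change on two cores in this assay, an at least 2.2-fold lower number (0.35 log units; beyond the scatter) from compound 3 to compound 2 and a 2.4-fold lower number (0.38 log units; beyond the scatter) from compound 1 to compound 4; the limit leaves it open whether they differ

Compound 3 gives > 20000 nM, which is a limit of the assay.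

Going by these compounds, only isopropyl and hydrogen appear at this place, and it stays open how a methyl group, a methoxy group or a chlorine atom would read there. Also open, on these data alone, is how the same change would read on a core carrying an amine or a carboxylic acid.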